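A tert-Butoxycarbonyl in Place of the Chloropyrimidine on Compound 3

This account rests on a few compounds, and the source may have more. Where it says the series, first, only, none or still open, it means among the compounds named here.

Three measured compounds share one core and differ in a single group. Compound 1 `CC(=O)c1cnc(N2CCC(c3coc4c(N5CCc6cc(S(C)(=O)=O)ccc65)ncnc34)CC2)nc1` gives 78 nM in a functional assay on cells for agonist activity at Glucose-dependent insulinotropic receptor (Homo sapiens), read by a luciferase reporter, with a stated time of 4 h; a lower number here means that less compound is needed, a higher number that more compound is needed for the effect. Compound 2 `CC(O)c1cnc(N2CCC(c3coc4c(N5CCc6cc(S(C)(=O)=O)ccc65)ncnc34)CC2)nc1`, with 1-hydroxyethyl in place of acetyl on an aromatic carbon, gives 586 nM in this assay, and compound 3 `CS(=O)(=O)c1ccc2c(c1)CCN2c1ncnc2c(C3CCN(c4ncc(Cl)cn4)CC3)coc12`, with chloro in that place, gives 42 nM in this assay. Compound 3 thus holds the lowest of the three numbers; its gap to compound 1 stays within the scatter, as a 1.9-fold lower number from compound 1 to compound 3 (0.27 log units; within the scatter) shows, whereas a 14-fold lower number from compound 2 to compound 3 (1.14 log units; beyond the scatter) is a large step. Compound 4 `CC(C)(C)OC(=O)N1CCC(c2coc3c(N4CCc5cc(S(C)(=O)=O)ccc54)ncnc23)CC1` differs from compound 3 by tert-butoxycarbonyl in place of 5-chloropyrimidin-2-yl on an amine nitrogen in a ring. For the measured compounds named here, no measured step covers this change: the measured steps, a 7.5-fold higher number from compound 1 to compound 2 (0.88 log units; beyond the scatter) among them, only alter a substituent on the very ring that now leaves, and so show that this region can shift the number. With the whole ring gone, the step of a 14-fold higher number from compound 3 to compound 4 (1.15 log units; beyond the scatter) is expected to raise the number in this assay. Compound 4 is therefore estimated at 600 nM, within a range from 80 nM to 4000 nM.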

Compound 4, half-maximal effective concentration: 53 nM
Estimate against measurement, compound 4: 11-fold (1.05 log units) above; measured number below the stated range.
By their numbers in this assay, from the lowest: compounds 3, 4 and 1 (each within the scatter of the next); then compound 2.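

In this assay, the amine nitrogen in the ring can carry tert-butoxycarbonyl, which has no ring, in place of 5-chloropyrimidin-2-yl without a shift beyond the scatter (a 1.3-fold higher number from compound 3 to compound 4 (0.10 log units; within the scatter)). The same holds against the 5-acetylpyrimidin-2-yl group (a 1.5-fold lower number from compound 1 to compound 4 (0.17 log units; within the scatter)), whereas the 5-(1-hydroxyethyl)pyrimidin-2-yl group stands clearly apart (an 11-fold lower number from compound 2 to compound 4 (1.04 log units; beyond the scatter)). Among these four compounds, an aromatic ring on this nitrogen is therefore not required for a number in this range, and compound 2 is the one that sits outside it.

Nothing available explains why such different groups give numbers within the scatter of one another. On these data alone, it also remains open whether a smaller acetyl group, a free amine or a carboxylic acid on a longer chain at this nitrogen would keep the number there.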